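Two Indole Variants at the Cytotoxicity Limit, and a Hybrid

A few compounds are considered here, and "the series" means these few. Any claim that something is new, unique, unknown or untested is made for them only; others in the source may bear on it.

Measured compounds:
Compound 1, `COc1ccc2[nH]cc(-c3cnc(N(C)[C@@H]4C[C@H]5O[C@@](C)([C@@H]4OC)n4c6ccccc6c6c7c(c8c9ccccc9n5c8c64)C(=O)NC7)s3)c2c1`, in an ADME assay on PBMC cells (Homo sapiens) for cytotoxicity, read by CellTiter-Glo, with a stated time of 72 h (on this read-out higher numbers stand for weaker inhibition and lower numbers for stronger inhibition), gives > 10000 nM.
Compound 2, `CO[C@@H]1[C@H](N(C)c2ncc(-c3c[nH]c4ccc(F)cc34)s2)C[C@H]2O[C@]1(C)n1c3ccccc3c3c4c(c5c6cc(Br)ccc6n2c5c31)C(=O)NC4`, in this assay gives > 10000 nM.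

Both of these values are limits of the assay rather than numbers. Compound 2 sits at its limit, and compound 1 sits at the same limit, so the limit of > 10000 nM in this assay, at which 2 of the 2 values shown sit, is the whole of what the measured values show; nothing here separates the two compounds.

Compound 3, `COc1ccc2[nH]cc(-c3cnc(N(C)[C@@H]4C[C@H]5O[C@@](C)([C@@H]4OC)n4c6ccccc6c6c7c(c8c9cc(Br)ccc9n5c8c64)C(=O)NC7)s3)c2c1`, has not yet been measured. It differs from compound 2 in one place: methoxy in place of fluoro on an aromatic carbon. The bromine on the shared core of compound 2 stays in place, so compound 3 carries the indole substituent of compound 1 together with the core of compound 2.

For the measured compounds named here, no step between measured compounds can be read off, since both values are limits. Given that both measured compounds sit at the limit, the step in this assay is expected to be none beyond the scatter, in no particular direction, with compound 3 most likely also reported only as a limit. The expected step is a step that the limit leaves unreadable from compound 2 to compound 3. Compound 3 is estimated to give 15000 nM, with a range from 7000 nM to 40000 nM.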

Compound 3, half-maximal inhibitory concentration: > 10000 nM
Compound 3 ended at the assay's limit; the forecaster's own chance of this, stated with the estimate: 85%; the middle value does not contradict the limit.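

For the compounds shown here, no step from compound 1 or compound 2 to compound 3 can be read in this assay, because all the values are limits of the assay rather than numbers: the limit of > 10000 nM in this assay, at which 3 of the 3 values shown sit. The compounds shown leave open how far each one lies beyond that limit, and so whether methoxy in place of fluoro, or bromo in place of hydrogen, changes the result in this assay at all.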